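The source may report more compounds than this note shows. Statements on the series, on what has been measured and on what is new or still open speak of the compounds shown alone.

Measured compounds, on a functional assay on MONO-MAC-6 cells (Homo sapiens) for inhibition; on this read-out higher numbers stand for weaker inhibition and lower numbers for stronger inhibition:
compound 1 `O=C(NO)[C@H]1CCCCN1S(=O)(=O)N1CC=C(c2ccc(Br)cc2)CC1` gives 1200 nM
compound 2 `COc1ccc(C2=CCN(S(=O)(=O)N3CCCC[C@@H]3C(=O)NO)CC2)cc1` gives 15000 nM
compound 3 `O=C(NO)[C@H]1CCCCN1S(=O)(=O)N1CC=C(c2ccc(-c3ccccc3)cc2)CC1` gives 19000 nM

Compound 3 carries the highest number of the three. Against compound 1 the step is a 16-fold higher number from compound 1 to compound 3 (1.20 log units; beyond the scatter), beyond the scatter. Against compound 2 the step is a 1.3-fold higher number from compound 2 to compound 3 (0.10 log units; within the scatter), within the scatter, so compounds 2 and 3 cannot be ordered.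

Compound 4 `O=C(NO)[C@H]1CCCCN1S(=O)(=O)N1CC=C(c2ccc(Oc3ccccc3)cc2)CC1` is not yet measured. The change from compound 3 is phenoxy in place of phenyl on an aromatic carbon. Among the measured compounds shown here, no measured step replaces phenyl by phenoxy directly. For the measured compounds named here, the steps that bear on it are those leading to compound 3: a 16-fold higher number from compound 1 to compound 3 (1.20 log units; beyond the scatter), a large step, and a 1.3-fold higher number from compound 2 to compound 3 (0.10 log units; within the scatter), within the scatter. Both a phenyl and an oxygen-linked group at this place already sit in the weak range, and phenoxy combines these features, so no step beyond the scatter is expected in this assay; a number near compound 3 or somewhat higher is the expectation.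

For compound 4 the estimate is 22000 nM, range 7000 nM to 70000 nM, which means an expected step of a 1.2-fold higher number from compound 3 to compound 4 (0.06 log units; within the scatter).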

Compound 4, half-maximal inhibitory concentration: 3300 nM
Compound 4: middle estimate off by 6.7-fold (0.82 log units), on the high side; measured number below the stated range.
By their numbers in this assay, from the lowest: compound 1; then compound 4; then compounds 2 and 3 (each within the scatter of the next).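

In this assay, phenoxy in place of phenyl on this aromatic carbon gives a 5.8-fold lower number from compound 3 to compound 4 (0.76 log units; beyond the scatter), so the outcome for an added aromatic ring here depends on how it is attached. Phenyl in place of methyl on the oxygen gives a 4.5-fold lower number from compound 2 to compound 4 (0.66 log units; beyond the scatter), and compound 4 therefore stands apart from both compound 2, which has the oxygen without the ring, and compound 3, which has the ring without the oxygen. Bromo still gives the lowest number of the four, with a 2.8-fold higher number from compound 1 to compound 4 (0.44 log units; beyond the scatter), so among the groups at this carbon the larger phenoxy recovers only part of the gap to compound 1.

Nothing available here accounts for these differences. Also open, going by these compounds, is how a benzyloxy group or an amine at this carbon would compare with bromo and phenoxy.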